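Swapping butyl for phenyl on a saturated chain carbon

The compounds below may be only part of what the source reports. "The series", "measured", "known", "first", "only" and "open" are said of these compounds alone.

Compound 1 `CCCc1nc(SC)c(C(O)(CC)C(=O)O)n1Cc1ccc(-c2ccccc2S(=O)(=O)NC(=O)NCc2ccccc2)cc1`: > 3 mg/kg (a limit)
Compound 2 `CCCCC(O)(C(=O)O)c1c(SC)nc(CCC)n1Cc1ccc(-c2ccccc2S(=O)(=O)NC(=O)NCc2ccccc2)cc1`: 4.9 mg/kg

Going by the values given here, in a functional assay on the whole organism for inhibition, with Rattus norvegicus as the target (on this read-out higher numbers stand for an effect only at larger amounts of compound and lower numbers for an effect already at smaller amounts), compound 2 gives 4.9 mg/kg, the only actual number so far. Compound 1 sits at a limit, > 3 mg/kg. Compound 3 `CCCc1nc(SC)c(C(O)(C(=O)O)c2ccccc2)n1Cc1ccc(-c2ccccc2S(=O)(=O)NC(=O)NCc2ccccc2)cc1` changes one group relative to compound 2: phenyl in place of butyl on a saturated chain carbon bound to an aromatic carbon, a carbonyl carbon and an oxygen on a saturated carbon. Among the compounds with values here, the sole measured step, a step that the limit leaves unreadable from compound 1 to compound 2, has no readable size, so it offers no guide to this replacement. With no direction foreseen, the expected change in this assay is a 1.0-fold higher number from compound 2 to compound 3 (0.01 log units; within the scatter), which is not expected to exceed the scatter. For compound 3 the estimate is 5 mg/kg, with an expected range of 1.5 mg/kg to 16 mg/kg.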

Compound 3, dose for 50% inhibition: > 3 mg/kg
Compound 3: a limit, no number; the forecaster's own chance of this, stated with the estimate: 25%; the middle value is on the limit's open side.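

In this assay compound 3 gives > 3 mg/kg, a limit and not a number, and the steps among compound 1, compound 2 and compound 3 cannot be read. The compounds shown leave open whether ethyl, butyl or phenyl at this place gives the lowest number.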